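The source may report more compounds than this note shows. Statements on the series, on what has been measured and on what is new or still open speak of the compounds shown alone.

compound 1 `CC#CCn1c(N2CCC[C@@H](N)C2)cc(=O)n(Cc2ccc(Cl)c(C(=O)O)c2)c1=O`: 0.91 h
compound 2 `CC#CCn1c(N2CCC[C@@H](N)C2)cc(=O)n(Cc2ccc(F)c(C(=O)O)c2)c1=O`: 0.96 h

In an ADME assay on the whole organism (Rattus norvegicus, strain Sprague-Dawley) for metabolic stability, read by LC-MS, with a stated time of 48 h, at a dose of 3 mg/kg by the intravenous route (a lower number here means that the compound disappears faster, a higher number that the compound lasts longer), compound 2 gives 0.96 h. Among the measured compounds shown here, only one other measurement is available for comparison, and compound 2 lies within the scatter of compound 1, so the two cannot be told apart on these numbers.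

The next compound, compound 3 `CC#CCn1c(N2CCC[C@@H](N)C2)cc(=O)n(Cc2ccc(Br)c(C(=O)O)c2)c1=O`, keeps everything the same except for one substituent. The change is bromo in place of fluoro on an aromatic carbon, ortho to a carboxy group and para to a large group.

For the measured compounds named here, one measured step bears on this change, as it swaps one halogen for another on the same carbon: a 1.1-fold higher number from compound 1 to compound 2 (0.02 log units; within the scatter). Going by the values given here, that step is small, and it is the only guide, since no bromo compound has been measured yet. Extending it to bromo is therefore a cautious assumption, and no shift beyond the scatter is expected. The expected change is a 1.1-fold lower number from compound 2 to compound 3 (0.03 log units; within the scatter). For compound 3 the estimated half-life is 0.9 h, with an expected range of 0.55 h to 1.5 h.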

Compound 3, half-life: 0.59 h
Beside the measured number, compound 3's estimate is 1.5-fold (0.18 log units) above it; the measured number falls inside the stated range.
By their numbers in this assay, from the lowest: compounds 3, 1 and 2 (each within the scatter of the next).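

With bromo on this aromatic carbon, ortho to a carboxy group and para to a large group, the series now spans fluoro, chloro and bromo at one position. In this assay, both new steps stay within the usual scatter: a 1.6-fold lower number from compound 2 to compound 3 (0.21 log units; within the scatter) and a 1.5-fold lower number from compound 1 to compound 3 (0.19 log units; within the scatter). Taken with the earlier fluoro and chloro pair, this means that none of the three compounds can be told apart by half-life, so choosing among these three halogens at this carbon has no clear effect on the reading, and nothing measured here offers any explanation for the small differences in the numbers.

On these data alone, all three compounds carry a single halogen atom at this carbon, so it remains open whether a methyl, methoxy or nitrile group there would move the half-life beyond the scatter. As far as these compounds go, it is equally open whether an amide or a tetrazole in place of the carboxy group would leave the half-life within the range seen for these three compounds.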